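This account rests on a few compounds, and the source may have more. Where it says the series, first, only, none or still open, it means among the compounds named here.

Measured in a functional assay on HepG2 cells (Homo sapiens) for cytotoxicity, read by MTT assay, with a stated time of 48 h; a lower number here means a stronger inhibitor, a higher number a weaker inhibitor:
- compound 1 `CC1=NN(C(=O)c2ccc(C)cc2)C(c2ccccc2O)C1`: 11300 nM
- compound 2 `CCN(CC)CC(=O)N1N=C(C)CC1c1ccccc1O`: 51600 nM

Going by the values given here, compound 2 has the higher of the two numbers, and its only neighbour is compound 1. Among the compounds with values here, the one measured step is a 4.6-fold higher number from compound 1 to compound 2 (0.66 log units; beyond the scatter).

Next in the series is compound 3 `CCN(CC)CC(=O)N1N=C(C)CC1c1ccccc1OC(C)=O`, which differs from compound 2 by acetyl in place of hydrogen on an oxygen on an aromatic ring. This is acetyl in place of hydrogen on an oxygen on an aromatic ring, or hydroxy to acetoxy.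

Within the data shown here, no measured compound shows a change at this oxygen. The step from compound 1 to compound 2 lies at the carbonyl carbon, so it bears only indirectly and gives only a rough idea of how far one substitution can move the number in this small set. That step was modest, and it says nothing about direction for the new change. In this assay, no step beyond the scatter is therefore expected, and the estimated step is a 1.1-fold lower number from compound 2 to compound 3 (0.06 log units; within the scatter). Among the measured compounds shown here, the range is kept wide on both sides, as only two measured values support it. Compound 3 is estimated at 45000 nM, with an expected range from 18000 nM to 110000 nM.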

Compound 3, half-maximal inhibitory concentration: 33200 nM
Estimate against measurement, compound 3: 1.4-fold (0.13 log units) above; low and high end bracket the measured number.
By their numbers in this assay, from the lowest: compound 1; then compounds 3 and 2 (each within the scatter of the next).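

In this assay, going by these compounds alone, the first change at the oxygen on the aromatic ring, acetyl in place of hydrogen, gives a 1.6-fold lower number from compound 2 to compound 3 (0.19 log units; within the scatter), so hydroxy and acetoxy cannot be told apart at this position on the diethylamino side chain of compound 2. Within the data shown here, this is the first sign that the free hydroxy hydrogen is not required for the number to stay within the scatter, at least with this one acetyl group, while a 4.6-fold higher number from compound 1 to compound 2 (0.66 log units; beyond the scatter) remains the only step beyond the scatter. No measurement available here bears on the reason for this result.

On these data alone, it remains open whether other groups on this oxygen, such as a methyl ether, a benzoyl ester or a longer acyl chain like hexanoyl, would also leave the number within the scatter or would move it in either direction. As far as these compounds go, it is also open whether acetyl on the same oxygen behaves in the same way when the 4-methylphenyl carbonyl group of compound 1 stands on the shared core in place of the diethylamino side chain.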